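A few compounds are considered here, and "the series" means these few. Any claim that something is new, unique, unknown or untested is made for them only; others in the source may bear on it.

Measured compounds in a functional assay on CHO cells for antagonist activity at transient receptor potential cation channel subfamily V member 1 (Rattus norvegicus); a lower number here means a stronger inhibitor, a higher number a weaker inhibitor:
- compound 1, `C[C@H](C(=O)NC[C@H](COC(=O)C(C)(C)C)Cc1ccccc1)c1ccc(NS(C)(=O)=O)c(F)c1`: 8.56 nM
- compound 2, `Cc1ccc(CC(CNC(=O)C(C)(C)c2ccc(NS(C)(=O)=O)cc2)COC(=O)C(C)(C)C)cc1C`: 104 nM
- compound 3, `Cc1ccc(CC(CNC(=O)C2(c3ccc(NS(C)(=O)=O)cc3)CC2)COC(=O)C(C)(C)C)cc1C`: 197 nM

Compound 1 stands lowest of the three numbers in this assay. Going by the values given here, the nearest value, that of compound 2, lies beyond the scatter above it, and the value of compound 3 lies further still; no single-point step connects compound 1 to either of them, so their gaps can only be read as they stand.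

Compound 4, `C[C@H](C(=O)NC[C@@H](COC(=O)C(C)(C)C)Cc1ccccc1)c1ccc(NS(C)(=O)=O)c(F)c1`, is the next compound in this assay. Against compound 1 the change is the two compounds have the same atoms and bonds and differ only in configuration as drawn: 1 of 2 stereo elements differ; a stereocentre at a saturated chain carbon is drawn R in compound 1 and S in compound 4. Among the compounds with values here, no pair of measured compounds differs by a single change, so no measured step gives the size of such an inversion. For a compound pair that differs only in configuration as drawn, the expectation is a step in this assay that goes beyond the scatter, toward a higher number, since compound 1 already holds the lowest value and carries the configuration drawn R at that chain carbon.

Compound 4 is therefore expected to be weaker than compound 1 in this assay, the estimated step being a 7.0-fold higher number from compound 1 to compound 4 (0.85 log units; beyond the scatter). The estimate for compound 4 is 60 nM, with a range from 15 nM to 300 nM.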

Compound 4, inhibition constant: 10 nM
The estimate for compound 4 lay 6.0-fold (0.78 log units) above the measured number; measured number outside the range, below it.
By their numbers in this assay, from the lowest: compounds 1 and 4 (each within the scatter of the next); then compounds 2 and 3 (each within the scatter of the next).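

In this assay, going by these compounds alone, the saturated chain carbon drawn R in compound 1 and S in compound 4 is the first position with a measured single-change step, and inverting it gives a 1.2-fold higher number from compound 1 to compound 4 (0.07 log units; within the scatter). Within the data shown here, at this carbon the two configurations are therefore not told apart in this assay, so the low number of compound 1 is not tied to the configuration drawn there, and the earlier compounds could not show this. The reading rests on a clean comparison, with nothing else in the structure to account for the step: the fact that compounds 1 and 4 differ only in the configuration as drawn.

As far as these compounds go, the second stereo element, at the carbon bearing the methyl group, is drawn alike in compound 1 and compound 4, so the effect of inverting it stays open, as does whether its configuration would be tolerated as readily as this one. Also open, from the compounds shown here alone, is whether this insensitivity to configuration would hold with a carboxylic acid or an amine in place of the ester group carried on the same chain, since both members of this pair keep that ester.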